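This account rests on a few compounds, and the source may have more. Where it says the series, first, only, none or still open, it means among the compounds named here.

Of the compounds shown here, three built on one shared core have been measured in a functional assay on GTL 16 cells for antiproliferative activity against GTL 16 cell line (Homo sapiens), read by CCK-8 assay, with a stated time of 72 h; a lower number here means a stronger inhibitor, a higher number a weaker inhibitor. Compound 1 `O=C(Nc1cccc(-c2oc3cc(-c4ccc(F)cc4)ccc3c(=O)c2O)c1)c1ccc(F)cc1` gives 14600 nM. Compound 2 `COc1ccc(C(=O)Nc2cccc(-c3oc4cc(-c5ccc(F)cc5)ccc4c(=O)c3O)c2)cc1` gives 21100 nM, and compound 3 `O=C(Nc1cccc(-c2oc3cc(-c4ccc(F)cc4)ccc3c(=O)c2O)c1)c1ccc(F)cc1F` gives 9640 nM. Among these three numbers compound 1 stands second highest; its nearest neighbour is compound 2, and the step of a 1.4-fold higher number from compound 1 to compound 2 (0.16 log units; within the scatter) lies within the scatter, as does a 1.5-fold lower number from compound 1 to compound 3 (0.18 log units; within the scatter). Only a 2.2-fold lower number from compound 2 to compound 3 (0.34 log units; beyond the scatter) reaches beyond it, and even that step is modest.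

Compound 4 `O=C(Nc1cccc(-c2oc3cc(-c4ccc(F)cc4)ccc3c(=O)c2O)c1)c1ccc(C(F)(F)F)cc1` is compound 1 with one change: trifluoromethyl in place of fluoro on an aromatic carbon. For the measured compounds named here, the change sits on an aromatic carbon of a six-membered aromatic ring of carbon only, para to a large group, so the steps that bear on it are the ones at that same ring, namely a 1.4-fold higher number from compound 1 to compound 2 (0.16 log units; within the scatter) and a 1.5-fold lower number from compound 1 to compound 3 (0.18 log units; within the scatter), where methoxy in place of fluoro and fluoro in place of hydrogen each moved the number only within the scatter. On that basis no step beyond the scatter is expected for this assay from compound 1 to compound 4, and the expected step is a 1.2-fold lower number from compound 1 to compound 4 (0.09 log units; within the scatter). Compound 4 is therefore estimated at 12000 nM, with a range from 5000 nM to 30000 nM, before the measurement is known.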

Compound 4, half-maximal inhibitory concentration: 33000 nM
For compound 4 the middle estimate is 2.8-fold (0.44 log units) below the measured one; the whole stated range lies below it.
By their numbers in this assay, from the lowest: compounds 3, 1, 2 and 4 (each within the scatter of the next, the first and the last beyond it).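

For the compounds shown here, until this result, no single change on this ring had moved compound 1 beyond the scatter, but trifluoromethyl in place of fluoro gives a 2.3-fold higher number from compound 1 to compound 4 (0.35 log units; beyond the scatter) in this assay and so shows that the place para to a large group does respond to what sits on it, if only modestly. The same group also opens the widest gap in the set, a 3.4-fold higher number from compound 3 to compound 4 (0.53 log units; beyond the scatter), yet a 1.6-fold higher number from compound 2 to compound 4 (0.19 log units; within the scatter) stays within the scatter, so the trifluoromethyl and methoxy compounds cannot be told apart here, even though only the trifluoromethyl group differs from fluoro by more than the scatter. Nothing among the data accompanying these numbers explains the step from fluoro to trifluoromethyl.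

On these data alone, whether a methyl, a nitrile, an amine or a carboxylic acid at this same place would stay close to compound 1 or move further from it remains open. Also open, as far as these compounds go, is whether the same swap would give a similar step on the other 4-fluorophenyl group, which stays unchanged in all four compounds.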